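A Bromine Added to Compound 2

The source may report more compounds than this note shows. Statements on the series, on what has been measured and on what is new or still open speak of the compounds shown alone.

Compound 2 `C=C1CC(c2ccccc2)N(C)C1=O` is the starting point. In a functional assay on NALM-6 cells (Homo sapiens) for cytotoxicity, read by MTT assay, with a stated time of 48 h (on this read-out higher numbers stand for weaker inhibition and lower numbers for stronger inhibition), compound 2 gives 553000 nM, the only number shown for it, beside a further entry that gives no single number. Compound 1 `C=C1C(=O)OC(c2ccccc2)C1C` gives 5420 nM; 7910 nM (2 entries) in this assay (the several entries of compound 1 in this assay, 5420 nM; 7910 nM (2 entries)). Compound 3 `C=C1CC(c2ccc(Br)cc2)N(C)C1=O` differs from compound 2 by bromo in place of hydrogen on an aromatic carbon. Among the measured compounds shown here, with no comparable step measured, the expected change is modest: a small gain in inhibition or none beyond the scatter. Compound 3 is therefore expected to give 250000 nM, between 60000 nM and 700000 nM, a step of a 2.2-fold lower number from compound 2 to compound 3 (0.34 log units; beyond the scatter).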

Compound 3, half-maximal inhibitory concentration: 141000 nM
The estimate for compound 3 lay 1.8-fold (0.25 log units) above the measured number; low and high end bracket the measured number.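

In this assay, bromo in place of hydrogen on an aromatic carbon, para to a group of 8 heavy atoms, gives a 3.9-fold lower number from compound 2 to compound 3 (0.59 log units; beyond the scatter). This is the first step shown at this position, and it shows that this aromatic carbon can carry a bromo group with a gain in inhibition beyond the scatter. Nothing given here accounts for the size of this step.

The compounds shown leave open whether chloro, methoxy or an amine at the same place would move the number in the same direction. They also leave open whether bromo would give a similar step on the core of compound 1.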